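A few compounds are considered here, and "the series" means these few. Any claim that something is new, unique, unknown or untested is made for them only; others in the source may bear on it.

Measured so far:
Compound 1 `COc1ccccc1-c1cc2c(n1-c1ccc(O)c(C(=O)O)c1)CCCC2` — 50%
Compound 2 `O=C(O)c1cc(-n2c(-c3ccc(Cl)c(Cl)c3)cc3c2CCCC3)ccc1O` — 0%

In a functional assay on the whole organism (strain Wistar) for inhibition, with Rattus norvegicus as the target, read by paw edema, with stated times of 30 min and 3 h, at a dose of 200 mg/kg by the oral route (on this read-out higher numbers stand for more inhibition at the one dose given (going by the name of the read-out) and lower numbers for less inhibition), compound 2 gives 0%, the lowest of the two numbers; compound 1 gives 50%. Compound 3 `N#Cc1ccc(-c2cc3c(n2-c2ccc(O)c(C(=O)O)c2)CCCC3)cc1` differs from compound 2 by 4-cyanophenyl in place of 3,4-dichlorophenyl on an aromatic carbon. Among the compounds with values here, the only measured step, a number 50 percentage points lower from compound 1 to compound 2 (beyond the scatter), swapped a different pair of groups at the same place on the shared core, so it shows how much that place can matter but does not tell which way 4-cyanophenyl will go. Compound 3 is therefore expected near 25%, within 0% to 55%. That expectation means a step of a number 25 percentage points higher from compound 2 to compound 3 (beyond the scatter).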

Compound 3, a percentage reported as inhibition, in the whole organism at one dose (the size of the read-out at that dose, not a potency): 0%
For compound 3 the middle estimate is 25 percentage points above the measured one, and the stated range covers the measured number.
By their numbers in this assay, from the lowest: compounds 2 and 3 (each within the scatter of the next); then compound 1.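

With no change at the digits printed from compound 2 to compound 3 (within the scatter), 4-cyanophenyl does no better than 3,4-dichlorophenyl at this place in this assay. Alongside a number 50 percentage points lower from compound 1 to compound 3 (beyond the scatter), this shows that the large loss seen earlier was not tied to 3,4-dichlorophenyl alone, since two different groups now both fall well short of 2-methoxyphenyl. No measurement given here explains this result. Still open, going by these compounds, is whether an unsubstituted phenyl or 4-methoxyphenyl at this place would read like compound 1 or like compound 3, and whether a 2-aminophenyl group could stand in for 2-methoxyphenyl.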